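Removing a Fluorine From a Cytotoxicity Screening Hit

A few compounds are considered here, and "the series" means these few. Any claim that something is new, unique, unknown or untested is made for them only; others in the source may bear on it.

Compound 1 `COc1ccc2nc(-c3ccc(C)c(N)c3)sc2c1` and compound 2 `Cc1ccc(-c2nc3ccc(F)cc3s2)cc1N` share one core and differ on a single aromatic carbon. In a functional assay on THP-1 cells (Homo sapiens) for cytotoxicity, read by MTT assay, with a stated time of 2 days (a lower number here means a stronger inhibitor, a higher number a weaker inhibitor), compound 1 gives a value that is a limit of the assay, > 50000 nM. In this assay compound 2 likewise gives only a limit, > 50000 nM. The step from compound 1 to compound 2, a step that the two limits leave unreadable from compound 1 to compound 2, therefore cannot be sized, because of the limit of > 50000 nM in this assay, at which 2 of the 2 values shown sit. Where compound 2 stands is thus known only as a limit, with no number beneath it.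

Compound 3 `Cc1ccc(-c2nc3ccccc3s2)cc1N` is not yet measured. It differs from compound 2 by hydrogen in place of fluoro on an aromatic carbon, the same carbon that carried methoxy in compound 1 and fluoro in compound 2. Among the compounds with values here, the one measured step at this position gives no readable size, so no direction can be drawn from it. The expectation for compound 3 in this assay is that it, too, sits at or beyond the limit, with the expected step that the limit leaves unreadable from compound 2 to compound 3 being no change beyond the scatter. Compound 3 is estimated at 80000 nM, within 30000 nM to 300000 nM.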

Compound 3, half-maximal inhibitory concentration: > 50000 nM
Compound 3 gave a limit, no number; the forecaster's own chance of this, stated with the estimate: 85%; the middle value does not contradict the limit.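

Compound 3, like compound 1 and compound 2, gives only a limit and no number, so neither step leading to compound 3 can be read: the limit of > 50000 nM in this assay, at which 3 of the 3 values shown sit.

The compounds shown leave open how hydrogen, fluoro and methoxy on this aromatic carbon compare in this assay, and whether any compound with the shared core gives a number there at all.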